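Removing a Selenium Methyl in a Cell Growth Screen

A few compounds are considered here, and "the series" means these few. Any claim that something is new, unique, unknown or untested is made for them only; others in the source may bear on it.

Compound 1 `COc1ccc(CNc2nc([Se]C)nc3ccccc23)cc1` was tested in an ADME assay on 184B5 cells (Homo sapiens) for cytotoxicity, read by MTT assay, with a stated time of 72 h; on this read-out lower numbers stand for stronger inhibition of growth and higher numbers for weaker inhibition of growth. In this assay compound 1 gives > 100000 nM, which is a limit of the assay rather than a measured number. Compound 2 `CCCCC[Se]c1nc([Se]CCCCC)c2cccnc2n1` in this assay gives > 100000 nM, likewise a limit. Every value shown so far sits at the limit of > 100000 nM in this assay, at which 2 of the 2 values shown sit. Compound 3 `COc1ccc(CNc2nc([SeH])nc3ccccc23)cc1` differs from compound 1 by hydrogen in place of methyl on a selenium. For the measured compounds named here, with no measured step to guide, the expected change is a number no higher from compound 1 to compound 3 (the limit leaves the size open), nothing beyond the scatter. Compound 3 is therefore estimated at 100000 nM, within 50000 nM to 200000 nM.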

Compound 3, concentration for total growth inhibition: > 100000 nM
Compound 3: no number, only a limit; the forecaster's own chance of this, stated with the estimate: 85%; the middle value sits exactly at the limit.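

For the compounds shown here, compound 3 sits at a limit just as compound 1 does, so no step from compound 1 to compound 3 can be read. All values shown rest at one ceiling: the limit of > 100000 nM in this assay, at which 3 of the 3 values shown sit.

What the compounds leave open is how strongly any of them inhibits growth, and whether swapping methyl for hydrogen on the selenium changes that at all.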